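Swapping the aryl group on a thioether-linked nucleoside

The source may report more compounds than this note shows. Statements on the series, on what has been measured and on what is new or still open speak of the compounds shown alone.

Two nucleoside analogues have been tested in an assay on isolated protein for binding affinity to Equilibrative nucleoside transporter 1 (Homo sapiens); a lower number here means a stronger inhibitor, a higher number a weaker inhibitor. Compound 1, `O=[N+]([O-])c1cccc2c1CCN(c1ncnc3c1ncn3[C@@H]1O[C@H](CO)[C@@H](O)[C@H]1O)C2`, carries a nitro-substituted bicyclic amine on the shared core; in this assay compound 1 gives 3020 nM. Compound 2, `OC[C@H]1O[C@@H](n2cnc3c(CSc4c(F)cccc4Cl)ncnc32)[C@H](O)[C@@H]1O`, instead links a 2-chloro-6-fluorophenyl group to the core through a sulfur attached to a saturated chain carbon, and in this assay compound 2 gives 1510 nM. Compound 2 has the lower of the two numbers, but its gap to compound 1 sits within the usual scatter, so no order between them can be claimed.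

Compound 3, `O=[N+]([O-])c1cccc(SCc2ncnc3c2ncn3[C@@H]2O[C@H](CO)[C@@H](O)[C@H]2O)c1`, keeps everything of compound 2 except the aryl group on the sulfur: 3-nitrophenyl in place of 2-chloro-6-fluorophenyl on a sulfur. Among the measured compounds shown here, no measured pair shows such a change directly, so the size of the step is open. A nitro-bearing aryl appears in compound 1 with 3020 nM, which is of the same order as compound 2, and on that slender basis the step of a 1.7-fold higher number from compound 2 to compound 3 (0.22 log units; within the scatter) is expected to stay within the scatter, or at most to be a modest weakening. Compound 3 is therefore estimated at 2500 nM, with a plausible range from 800 nM to 8000 nM.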

Compound 3, half-maximal inhibitory concentration: 4.79 nM
For compound 3 the middle estimate is 520-fold (2.72 log units) above the measured one; the whole stated range lies above it.
By their numbers in this assay, from the lowest: compound 3; then compounds 2 and 1 (each within the scatter of the next).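

In this position the aryl group on the sulfur has a very large influence: in this assay, 3-nitrophenyl in place of 2-chloro-6-fluorophenyl gives a 320-fold lower number from compound 2 to compound 3 (2.50 log units; beyond the scatter), a step far beyond the scatter. The rest of the molecule stays the same in this pair. Among the compounds shown here, no earlier pair had tested this position. Still, the swap removes the chlorine and fluorine and brings in the nitro group in a single move, so this one pair cannot assign the gain to any one part of the change, and no measurement shown explains it.

Going by these compounds, it remains open whether the nitro group is essential or whether other aryl groups on the sulfur, such as plain phenyl, 3-aminophenyl or 3-cyanophenyl, would give similarly low numbers. Also unresolved is how much the link itself contributes, which could be probed by putting an oxygen in place of the sulfur or a longer carbon chain between the sulfur and the shared core.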